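The source may hold more compounds than are shown below. What is called first, only, known or untested is meant among the compounds shown, and "the series" means these compounds.

Measured so far in an ADME assay on PANC-1 cells (Homo sapiens) for inhibition, read by MTT assay; a lower number here means a stronger inhibitor of growth, a higher number a weaker inhibitor of growth:
compound 1 `Cc1nc(-c2ccc(F)cc2)oc1-c1csc(Cc2ccccc2)n1`: > 250 ug/mL
compound 2 `Cc1nc(-c2ccccc2)oc1-c1csc(-c2ccccc2)n1`: > 250 ug/mL

Both values are limits of this assay, not numbers. Compound 2 stands at the limit of this assay. Compound 1 stands at the same limit. For the measured compounds named here, both known values sit at the limit of > 250 ug/mL in this assay, at which 2 of the 2 values shown sit, so no measured step exists.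

Compound 3 `Cc1nc(-c2ccccc2)oc1-c1csc(Cc2ccc(Cl)cc2)n1` differs from compound 2 by 4-chlorobenzyl in place of phenyl on an aromatic carbon. With the known values resting at the limit, no step beyond the scatter is expected in this assay in either direction. Compound 3 is expected at 300 ug/mL, within 100 ug/mL to 1000 ug/mL. The expected step that the limit leaves unreadable from compound 2 to compound 3 is essentially none, and a further limit is the likely read-out.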

Compound 3, concentration for 50% growth inhibition: > 250 ug/mL
Compound 3 gave a limit, no number; the forecaster's own chance of this, stated with the estimate: 85%; the middle value does not contradict the limit.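

Compound 2 and compound 3 both rest at a limit in this assay, so no step can be read between them: the limit of > 250 ug/mL in this assay, at which 3 of the 3 values shown sit.

The compounds shown leave open which change on the shared core, if any, would give a readable value in this assay at all.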